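Swapping cyclopentyl for 4-ethylphenyl on the shared core

A few compounds are considered here, and "the series" means these few. Any claim that something is new, unique, unknown or untested is made for them only; others in the source may bear on it.

All values come from a functional assay on HeLa cells (Homo sapiens) for inhibition, read by sulforhodamine B assay; a higher number here means a weaker inhibitor, a lower number a stronger inhibitor.
- compound 1 `O=C1C=C(NCc2ccccc2)C(=O)c2c1nc1n2[C@H]2OC[C@@H](O)[C@H]2OC1`: > 8000 nM (a limit)
- compound 2 `O=C1C(Nc2ccccc2F)=CC(=O)c2c1nc1n2[C@H]2OC[C@@H](O)[C@H]2OC1`: 9820 nM
- compound 3 `O=C1C(NC2CCCC2)=CC(=O)c2c1nc1n2[C@H]2OC[C@@H](O)[C@H]2OC1`: > 16000 nM (a limit)

Compound 3 gives > 16000 nM, which is a limit of the assay and not a number. Compound 1 gives > 8000 nM, which is also a limit. Of the three, only compound 2 has a measured number, so compound 3 has no exact place on the scale.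

The next compound is compound 4 `CCc1ccc(NC2=CC(=O)c3c(nc4n3[C@H]3OC[C@@H](O)[C@H]3OC4)C2=O)cc1`. It keeps the shared core and changes one group: 4-ethylphenyl in place of cyclopentyl on an amine nitrogen. In words, this is 4-ethylphenyl in place of cyclopentyl on an amine nitrogen.

Within the data shown here, one measured step bears on this change, and it runs the opposite way, from a substituted phenyl group to cyclopentyl: an at least 1.6-fold higher number from compound 2 to compound 3 (0.21 log units; that floor lies within the scatter). From the compounds shown here alone, that size is only a floor, so the true size of the step remains unknown. Compound 4 also carries a substituted phenyl group, although a different one, so a modest move to a lower number in this assay is expected, towards compound 2 at 9820 nM. The change may still stay within the scatter, or the assay may again report only a limit.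

The estimated step is an at least 1.7-fold lower number from compound 3 to compound 4 (0.24 log units; that floor lies within the scatter). For compound 4 the expected value is 9000 nM, with an estimated range from 3500 nM to 22000 nM.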

Compound 4, half-maximal inhibitory concentration: 6510 nM
For compound 4 the middle estimate is 1.4-fold (0.14 log units) above the measured one, and the stated range covers the measured number.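

With this assay as the read-out, the change at this amine nitrogen now gives a step beyond the scatter, which the earlier comparison of these groups could not show: an at least 2.4-fold lower number from compound 3 to compound 4 (0.39 log units; beyond the scatter). Compound 3 gives > 16000 nM, which is a limit of the assay and not a number, so this step is only a floor and its true size stays unknown: the limit of > 16000 nM in this assay, at which 1 of the 4 values shown sits. The two substituted phenyl groups, however, cannot be told apart in this assay, since a 1.5-fold lower number from compound 2 to compound 4 (0.18 log units; within the scatter), so the compounds shown do not separate 4-ethylphenyl from 2-fluorophenyl on this nitrogen.

The compounds shown leave open whether a plain phenyl group, or a phenyl group carrying a methoxy group or a carboxylic acid, would fall close to compound 2 and compound 4 or nearer the limit of compound 3. They also leave open whether an open-chain group such as butyl would behave more like cyclopentyl or more like the substituted phenyl groups, and how far the number can fall with any group on this nitrogen.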